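The source may hold more compounds than are shown below. What is called first, only, known or untested is meant among the compounds shown, and "the series" means these compounds.

Working notes on the urea series. Three compounds with a shared core have been run in a functional assay on HCT-116 cells (Homo sapiens) for inhibition, read by MTT assay, with a stated time of 2 days, tested at 10 uM; on this read-out lower numbers stand for less inhibition of growth and higher numbers for more inhibition of growth at the one concentration tested. Compound 1 `CNC(=O)c1cc(Oc2ccc3nc(NC(=O)Nc4cc(C(F)(F)F)cc(C(F)(F)F)c4)sc3c2)ccn1` gives 87.5%. Compound 2 `CNC(=O)c1cc(Oc2ccc3nc(NC(=O)Nc4ccc(Cl)cc4)sc3c2)ccn1` gives 57.4%. Compound 3 `CNC(=O)c1cc(Oc2ccc3nc(NC(=O)Nc4ccc(C5CCN(C(C)C)CC5)cc4)sc3c2)ccn1` gives 68.1%, which places compound 3 second of the three, between the other two. For the measured compounds named here, the only single-point step measured so far is a number 10.7 percentage points higher from compound 2 to compound 3 (beyond the scatter).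

Compound 4 `CNC(=O)c1cc(Oc2ccc3nc(NC(=O)Nc4ccc(F)cc4)sc3c2)ccn1` is not yet measured. Its change from compound 3 is fluoro in place of 1-isopropylpiperidin-4-yl on an aromatic carbon. Going by the values given here, no measured step covers this exact exchange. The nearest guide is the step from compound 2 to compound 3, which runs in the opposite direction to the present change and was modest, beyond the scatter. Compound 2 carries a single halogen at the same place and sits lowest of the three, so the expectation for compound 4 is a step down, of about the size a number 13.1 percentage points lower from compound 3 to compound 4 (beyond the scatter), rather than none beyond the scatter.

Compound 4 is therefore estimated at 55%, with a plausible range from 35% to 75%.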

Compound 4, percent growth inhibition at one concentration: 12.2%
Beside the measured number, compound 4's estimate is 42.8 percentage points above it; the measured number lies below the stated range.
By their numbers in this assay, from the lowest: compound 4; then compound 2; then compound 3; then compound 1.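

In this assay the identity of the halogen on this aromatic carbon carries much of the outcome: fluoro in place of chloro gives a number 45.2 percentage points lower from compound 2 to compound 4 (beyond the scatter) and so the two halogens cannot be treated as interchangeable here. Fluoro in place of 1-isopropylpiperidin-4-yl gives a number 55.9 percentage points lower from compound 3 to compound 4 (beyond the scatter) against the earlier a number 10.7 percentage points higher from compound 2 to compound 3 (beyond the scatter) and so, at this position, chloro and 1-isopropylpiperidin-4-yl stand much closer to each other than either stands to fluoro. Nothing on hand accounts for the low number of compound 4.

From the compounds shown here alone, whether that low number belongs to fluoro alone remains open, since bromo or methoxy on the same carbon would test how far it extends. Also open, going by these compounds, is whether an open-chain amine such as dimethylaminomethyl would hold the number of compound 3 without the piperidine ring.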